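A Phenoxy Analogue in a Kinetic Solubility Series

The compounds below may be only part of what the source reports. "The series", "measured", "known", "first", "only" and "open" are said of these compounds alone.

Measured compounds:
compound 1, `CCOc1cc(-c2ccnc(N)n2)cc2[nH]nc(N)c12`: 861000 nM
compound 2, `Nc1nccc(-c2cc(OC3CCOCC3)c3c(N)n[nH]c3c2)n1`: 770000 nM

In a physicochemical assay for solubility, read by LC-MS, in phosphate buffer, measured as kinetic solubility, with a stated time of 24 h, at 25 degrees C, at pH 7.4 (a higher number here means a more soluble compound, a lower number a less soluble compound), compound 1 gives 861000 nM and compound 2 gives 770000 nM. Compound 2 stands beside compound 1 on these numbers; the step of a 1.1-fold lower number from compound 1 to compound 2 (0.05 log units; within the scatter) is within the scatter, so the two are not separated by this assay.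

Compound 3, `Nc1nccc(-c2cc(Oc3ccccc3)c3c(N)n[nH]c3c2)n1`, has not yet been measured. It differs from compound 2 by phenyl in place of oxan-4-yl on an oxygen on an aromatic ring. For the measured compounds named here, only one measured step is available, a 1.1-fold lower number from compound 1 to compound 2 (0.05 log units; within the scatter), and it exchanged one non-aromatic group for another on the same oxygen while moving the number very little. Going by the values given here, no measured step exchanges a non-aromatic ring for an aromatic one, so its bearing on compound 3 is indirect. Compound 3 is nonetheless expected to give 200000 nM, within 50000 nM to 700000 nM. That estimate amounts to an expected step of a 3.9-fold lower number from compound 2 to compound 3 (0.59 log units; beyond the scatter), beyond the scatter and downward.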

Compound 3, solubility: 117000 nM
Compound 3: middle estimate off by 1.7-fold (0.23 log units), on the high side; the measured number falls inside the stated range.
By their numbers in this assay, from the lowest: compound 3; then compounds 2 and 1 (each within the scatter of the next).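

In this assay the group on this oxygen now separates the compounds: phenyl in place of oxan-4-yl gives a 6.6-fold lower number from compound 2 to compound 3 (0.82 log units; beyond the scatter) and sets compound 3 apart, and phenyl in place of ethyl gives a 7.4-fold lower number from compound 1 to compound 3 (0.87 log units; beyond the scatter) with the same outcome. Compound 1 and compound 2 had stayed within the scatter of each other despite carrying different non-aromatic groups, so this position is not indifferent to every exchange; the aromatic ring is the one group shown here that moves the number beyond the scatter.

The compounds shown leave open whether this belongs to aromatic rings in general or to phenyl alone. A pyridyl ring on the same oxygen, or a phenyl ring carrying an amine or a carboxylic acid, would bear on that question. Nothing available here explains the size of the step.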